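The source may report more compounds than this note shows. Statements on the series, on what has been measured and on what is new or still open speak of the compounds shown alone.

Measured so far:
compound 1, `Cc1ccc2nc(C)n(-c3ccc(C(=O)NC4CC4)s3)c2c1`: > 72 mL/min/kg
compound 2, `Cc1nc2c(Cl)cccc2n1-c1ccc(C(=O)NC2CC2)s1`: 19 mL/min/kg
compound 3, `Cc1cc(F)c2nc(C)n(-c3ccc(C(=O)NC4CC4)s3)c2c1`: > 72 mL/min/kg

Of the compounds shown here, three have been measured in an in vitro ADME assay on microsomes from liver (Mus musculus) for pharmacokinetics, read by LC-MS; on this read-out lower numbers stand for slow clearance and higher numbers for fast clearance. Compound 1, `Cc1ccc2nc(C)n(-c3ccc(C(=O)NC4CC4)s3)c2c1`, gives > 72 mL/min/kg in this assay, which is a limit of the assay and not a number. Compound 3, `Cc1cc(F)c2nc(C)n(-c3ccc(C(=O)NC4CC4)s3)c2c1`, also gives > 72 mL/min/kg in this assay, again a limit and not a number. For the measured compounds named here, compound 2, `Cc1nc2c(Cl)cccc2n1-c1ccc(C(=O)NC2CC2)s1`, is the one compound with an actual number, giving 19 mL/min/kg in this assay.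

Compound 3 arises from compound 1 by fluoro in place of hydrogen on an aromatic carbon, and the step that the two limits leave unreadable from compound 1 to compound 3 cannot be read because of the limit of > 72 mL/min/kg in this assay, at which 2 of the 3 values shown sit.

The difference between the core of compound 1 and the core of compound 2 is not broken down here.

Compound 4, `Cc1nc2c(Cl)cc(F)cc2n1-c1ccc(C(=O)NC2CC2)s1`, has not yet been measured. It arises from compound 2 by fluoro in place of hydrogen on an aromatic carbon, the same kind of change as that from compound 1 to compound 3, though the surroundings differ: in compound 4 the fluoro enters meta to a chloro group, meta to a fused ring and para to a fused ring, whereas in compound 3 it enters ortho to a fused ring, meta to a fused ring and meta to a methyl group.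

Since the measured step of this kind is unreadable, the expectation for compound 4 rests on the value of compound 2, 19 mL/min/kg, with only a small shift expected, a 1.1-fold lower number from compound 2 to compound 4 (0.02 log units; within the scatter). Compound 4 is therefore estimated to give 18 mL/min/kg in this assay, expected to fall between 7 mL/min/kg and 48 mL/min/kg.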

Compound 4, clearance: 42 mL/min/kg
For compound 4 the middle estimate is 2.3-fold (0.37 log units) below the measured one; low and high end bracket the measured number.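

In this assay, fluoro in place of hydrogen on an aromatic carbon of the core of compound 2 gives a 2.2-fold higher number from compound 2 to compound 4 (0.34 log units; beyond the scatter), so on this core the change moves the read-out towards faster clearance. The same change on the core of compound 1 cannot be read, because compound 1 and compound 3 both stand at a limit of the assay and not at a number: the limit of > 72 mL/min/kg in this assay, at which 2 of the 4 values shown sit. This leaves a single readable step of this kind, which shows what fluoro does in one setting, meta to a chloro group and para to a fused ring, but does not show whether the change carries from one core to the other, in size or in direction, and the fluoro also sits in different surroundings on the two cores.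

The compounds shown leave open how a nitrile or a methoxy group on that same aromatic carbon of the core of compound 2 would read in this assay. They also leave open whether fluoro on another aromatic carbon of that core would give a step of similar size.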